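The compounds below may be only part of what the source reports. "The series", "measured", "known", "first", "only" and "open" are said of these compounds alone.

Compound 1 `CSc1ccc(NC(=O)N[C@H]2CC[C@H](Oc3ccc(F)cc3)CC2)cc1` gives > 20000 nM in a functional assay on CRL2813 cells (Homo sapiens) for cytotoxicity, read by sulforhodamine B assay, with a stated time of 5 days (a lower number here means a stronger inhibitor, a higher number a weaker inhibitor), a limit of the assay.
Compound 2 `COc1ccc(NC(=O)N[C@H]2CC[C@H](Oc3ccc(F)cc3)CC2)cc1` gives > 20000 nM in this assay, also a limit.
Compound 3 `O=C(Nc1cccc(I)c1)N[C@H]1CC[C@H](Oc2ccc(F)cc2)CC1` gives 5200 nM in this assay.

For the measured compounds named here, compound 3 holds the only actual number here; the other two values sit at the limit of > 20000 nM in this assay, at which 2 of the 3 values shown sit. Compound 4 `CSc1cccc(NC(=O)N[C@H]2CC[C@H](Oc3ccc(F)cc3)CC2)c1` differs from compound 3 by methylsulfanyl in place of iodo on an aromatic carbon. The steps that touch this change are an at least 3.8-fold lower number from compound 1 to compound 3 (0.58 log units; beyond the scatter) and an at least 3.8-fold lower number from compound 2 to compound 3 (0.58 log units; beyond the scatter), in which 3-iodophenyl replaced 4-(methylsulfanyl)phenyl or 4-methoxyphenyl; neither separates the group from its place on the ring, and the step that the two limits leave unreadable from compound 1 to compound 2 cannot be read. With methylsulfanyl returning, the expectation for compound 4 is a modest weakening, a 1.9-fold higher number from compound 3 to compound 4 (0.28 log units; within the scatter). Compound 4 is therefore estimated at 10000 nM, between 3000 nM and 30000 nM.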

Compound 4, half-maximal inhibitory concentration: 11100 nM
Estimate against measurement, compound 4: 1.1-fold (0.05 log units) below, and the stated range covers the measured number.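

With the place on the ring held fixed, methylsulfanyl in place of iodo gives a 2.1-fold higher number from compound 3 to compound 4 (0.33 log units; beyond the scatter) in this assay, so the choice of group alone changes the number here. The change from 4-(methylsulfanyl)phenyl to 3-(methylsulfanyl)phenyl gives an at least 1.8-fold lower number from compound 1 to compound 4 (0.25 log units; that floor lies within the scatter), and 3-(methylsulfanyl)phenyl in place of 4-methoxyphenyl gives an at least 1.8-fold lower number from compound 2 to compound 4 (0.25 log units; that floor lies within the scatter). These two steps are only floors and do not settle how much the place matters, because compound 1 and compound 2 each sit at a limit: the limit of > 20000 nM in this assay, at which 2 of the 4 values shown sit.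

As far as these compounds go, how an amine or a longer chain at this same place would compare remains open.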